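A few compounds are considered here, and "the series" means these few. Any claim that something is new, unique, unknown or untested is made for them only; others in the source may bear on it.

Working notes on the series. In a functional assay on SEM cells (Homo sapiens) for cytotoxicity, with a stated time of 72 h (on this read-out lower numbers stand for an effect already at smaller amounts and higher numbers for an effect only at larger amounts of compound), compound 1 `C=C[C@@](C)(/C=C/c1ccc(O)c(CO)c1)CCC=C(C)C` gives > 36600 nM, which is a limit and not a number. For the measured compounds named here, compound 2 `C=C[C@@](C)(/C=C/c1ccc(O)c(/C=C/C(=O)c2ccccc2)c1)CCC=C(C)C` gives 8000 nM, the only true number so far. Compound 3 `C=C[C@@](C)(/C=C/c1ccc(O)c(/C=C/C(=O)OCC)c1)CCC=C(C)C` is not yet measured. It departs from compound 2 by ethoxy in place of phenyl on a carbonyl carbon. Going by the values given here, no measured step covers this change, and the data give only a weak basis for any forecast. A modest rise in this assay is expected, estimated as a 1.8-fold higher number from compound 2 to compound 3 (0.24 log units; within the scatter). The expected value for compound 3 is 14000 nM, with an estimated range of 5500 nM to 36000 nM.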

Compound 3, half-maximal effective concentration: > 36600 nM
Compound 3: only a limit was reported (the forecaster's own chance of this, stated with the estimate: 25%); middle value at least 2.6-fold (0.41 log units) from the limit.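

In this assay, for the compounds shown here, ethoxy in place of phenyl on a carbonyl carbon gives an at least 4.5-fold higher number from compound 2 to compound 3 (0.66 log units; beyond the scatter), so the only true number so far rests on the benzoyl group of compound 2. The size of this step is bounded from one side only: the limit of > 36600 nM in this assay, at which 2 of the 3 values shown sit. The step from compound 1 to compound 3 cannot be read, as both values are limits.

Going by these compounds, it remains open whether the phenyl ring or the ketone carbonyl carries the difference. A methyl ketone or an amide on this carbonyl carbon would separate the two.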